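The source may report more compounds than this note shows. Statements on the series, on what has been measured and on what is new or still open speak of the compounds shown alone.

Measured compounds and their values in an assay on CHO-TREX cells for antagonist activity at transient receptor potential cation channel subfamily A member 1 (Homo sapiens), read by FLIPR and calcium flux, with a stated time of 10 min; a higher number here means a weaker inhibitor, a lower number a stronger inhibitor:
- compound 1, `FC(F)(F)c1ccccc1-c1ccc2[nH]ncc2c1`, gives 164 nM
- compound 2, `FC(F)c1ccccc1-c1ccc2[nH]ncc2c1`, gives 2200 nM
- compound 3, `Fc1c(-c2ccccc2C(F)(F)F)ccc2[nH]ncc12`, gives 296 nM

Compound 1 gives the lowest number of the three. Compound 3 stands nearest, with a 1.8-fold higher number from compound 1 to compound 3 (0.26 log units; within the scatter), a gap that falls within the scatter. Compound 2 stands furthest, with a 13-fold higher number from compound 1 to compound 2 (1.13 log units; beyond the scatter), a gap beyond the scatter.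

Compound 4, `FC(F)(F)Oc1cc2[nH]ncc2cc1-c1ccccc1C(F)(F)F`, has not been measured. Its difference from compound 1 is trifluoromethoxy in place of hydrogen on an aromatic carbon. Within the data shown here, only one measured step touches the shared core: the change from compound 1 to compound 3, which was within the scatter. Among the measured compounds shown here, no measured step places a trifluoromethoxy group anywhere, and none changes the core at the position used here, so the size of the step is not anchored by a close precedent. On this basis compound 4 is expected to land near compound 1, with a step of a 1.5-fold higher number from compound 1 to compound 4 (0.18 log units; within the scatter) in this assay that is not expected to exceed the scatter. The estimate for compound 4 is 250 nM, in a range from 80 nM to 800 nM.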

Compound 4, half-maximal inhibitory concentration: 36 nM
The estimate for compound 4 lay 6.9-fold (0.84 log units) above the measured number, and the stated range ends above it.
By their numbers in this assay, from the lowest: compound 4; then compounds 1 and 3 (each within the scatter of the next); then compound 2.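

In this assay, trifluoromethoxy in place of hydrogen on this aromatic carbon, ortho to a large group, gives a 4.6-fold lower number from compound 1 to compound 4 (0.66 log units; beyond the scatter) and so moves the number beyond the scatter. The other change shown on the shared core, fluoro in place of hydrogen with a 1.8-fold higher number from compound 1 to compound 3 (0.26 log units; within the scatter), stayed within the scatter, so this position is where the core of compound 1 is seen to accept a substituent of 5 heavy atoms with a gain in inhibition. The data shown hold no measurement that could explain this step.

From the compounds shown here alone, whether methoxy, a nitrile or an amine on this same aromatic carbon would lower the number as well remains open. Also open, going by these compounds, is whether trifluoromethoxy here would give a similar step alongside the side group of compound 2 in place of the trifluoromethyl of compound 1.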